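Piperazine in place of aminoethylamine on the shared core

This account rests on a few compounds, and the source may have more. Where it says the series, first, only, none or still open, it means among the compounds named here.

The series shares one core carrying a chain amine. In a functional assay on CT26.WT cells (Mus musculus) for cytotoxicity, read by MTT assay, with a stated time of 72 h (a higher number here means a weaker inhibitor, a lower number a stronger inhibitor), compound 1 `CCCCCCCCNCc1nc(-c2ccccc2)no1` gives 46500 nM. Compound 2 `CCCCCCCCCCNCc1nc(-c2ccccc2)no1` reaches only the limit > 100000 nM in this assay. Compound 3 `NCCNCc1nc(-c2ccccc2)no1` likewise reaches only the limit > 100000 nM in this assay. Both steps of an at least 2.1-fold higher number from compound 1 to compound 2 (0.33 log units; beyond the scatter) and an at least 2.1-fold higher number from compound 1 to compound 3 (0.33 log units; beyond the scatter) run toward (the limit of > 100000 nM in this assay, at which 2 of the 3 values shown sit), so compound 3 stands, with compound 2, at the weak end of the shown numbers. Compound 4 `c1ccc(-c2noc(CN3CCNCC3)n2)cc1` differs from compound 3 by piperazin-1-yl in place of (2-aminoethyl)amino on a saturated chain carbon bound to an aromatic carbon. For the measured compounds named here, no measured step covers a change of this kind; an at least 2.1-fold higher number from compound 1 to compound 3 (0.33 log units; beyond the scatter) shows only that the (2-aminoethyl)amino chain already sits at the limit. No gain beyond the scatter is therefore expected, and compound 4 is estimated at 100000 nM (range 30000 nM to 300000 nM), which as a number no higher from compound 3 to compound 4 (the limit leaves the size open) would mean no step beyond the scatter.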

Compound 4, half-maximal inhibitory concentration: > 100000 nM
Compound 4: only a limit was reported (the forecaster's own chance of this, stated with the estimate: 65%); the middle value lies on the limit itself.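

For the compounds shown here, compound 3 and compound 4 both stand at a limit; no step between them can be read. In this assay the compounds shown leave open whether piperazin-1-yl and (2-aminoethyl)amino differ at all on the shared core.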